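Cytotoxicity on MT4 cells: removing a side chain

A few compounds are considered here, and "the series" means these few. Any claim that something is new, unique, unknown or untested is made for them only; others in the source may bear on it.

The measured compounds and their values:
compound 1, `CN1CCN(CC(=O)Nc2ccc(-c3nc4cc(Cl)c(Cl)cc4[nH]3)cc2)CC1`: 11000 nM
compound 2, `CN1CCN(CC(=O)Nc2ccc(-c3nc4cc(C(F)(F)F)ccc4n3C)cc2)CC1`: 22000 nM
compound 3, `Nc1ccc(-c2nc3cc(Cl)c(Cl)cc3[nH]2)cc1`: 17000 nM

All three were tested in an ADME assay on MT4 cells (Homo sapiens) for cytotoxicity, read by MTT assay, with a stated time of 96 h; a higher number here means that more compound is tolerated, a lower number that less compound is tolerated. Compound 2 gives the highest of the three numbers, yet its gap to compound 3 and its gap to compound 1 are both within the usual scatter of this assay, so no order among the three can be claimed. Compound 4, `Cn1c(-c2ccc(N)cc2)nc2cc(C(F)(F)F)ccc21`, is the partner of compound 2 without the side chain.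

The change from compound 2 to compound 4 is hydrogen in place of ((4-methylpiperazin-1-yl)methyl)carbonyl on a nitrogen on an aromatic ring. A comparable pairing exists already among the measured compounds: compound 3 carries a free amine where compound 1 carries the same side chain. Compound 3 gives 17000 nM. Compound 1 gives 11000 nM. The two values lie within the scatter of each other.

On that basis no step beyond the scatter is expected from compound 2 to compound 4 in this assay; the estimated step of a 1.2-fold lower number from compound 2 to compound 4 (0.09 log units; within the scatter) is small. Compound 4 is expected to give about 18000 nM, with a range from 9000 nM to 40000 nM.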

Compound 4, half-maximal cytotoxic concentration: 20000 nM
The estimate for compound 4 lay 1.1-fold (0.05 log units) below the measured number, within the range that was stated.
By their numbers in this assay, from the lowest: compounds 1, 3, 4 and 2 (each within the scatter of the next).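

In this assay the exchange of ((4-methylpiperazin-1-yl)methyl)carbonyl for hydrogen on a nitrogen on an aromatic ring can now be read directly on the core of compound 2 as a 1.1-fold lower number from compound 2 to compound 4 (0.04 log units; within the scatter) and so does not separate the side chain from the free amine on this core. Earlier, the same exchange could be followed only on the core of compound 1, where compound 1 gives 11000 nM and compound 3 gives 17000 nM and these two values lie within the scatter of each other; the result therefore extends this observation to a second core, and no compound shown goes against it. No supporting data are available that bear on this result.

The compounds shown leave open whether other groups on this nitrogen, such as an acetyl group or a longer chain ending in a morpholine ring, would also stay within the scatter of the free amine. They also leave open how the chlorine atoms, the trifluoromethyl group and the methyl group on the core each count alone, as the two cores differ in more than one place.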